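The compounds below may be only part of what the source reports. "The series", "measured", "known", "first", "only" and "open" are said of these compounds alone.

Going by the values given here, compound 1 `CN(c1ccc2cc(NC(=O)CCc3ccc(C(F)(F)F)cc3)ccc2n1)C1CCCCC1` gives 1200 nM in a functional assay on HEK293 cells for activation of melanin-concentrating hormone receptor 1 (Rattus norvegicus), read by inositol phosphate accumulation (a higher number here means that more compound is needed for the effect, a lower number that less compound is needed), the highest of the three numbers measured so far. Compound 2 `CN(C)c1ccc2cc(NC(=O)CCc3ccc(C(F)(F)F)cc3)ccc2n1` gives 110 nM in this assay, and compound 3 `CC(C)N(C)c1ccc2cc(NC(=O)CCc3ccc(C(F)(F)F)cc3)ccc2n1` gives 140 nM. Between them there is an 11-fold lower number from compound 1 to compound 2 (1.04 log units; beyond the scatter) and an 8.6-fold lower number from compound 1 to compound 3 (0.93 log units; beyond the scatter), while a 1.3-fold higher number from compound 2 to compound 3 (0.10 log units; within the scatter).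

Compound 4 `O=C(CCc1ccc(C(F)(F)F)cc1)Nc1ccc2nc(N3CCC(c4ccccc4)C3)ccc2c1` is the next candidate; compared with compound 1, (3-phenylpyrrolidin-1-yl in place of cyclohexyl(methyl)amino on an aromatic carbon). Both measured steps from compound 1 replace cyclohexyl on the nitrogen with a smaller group and give large drops, so the cyclohexyl(methyl)amino group of compound 1 marks the high end of the series. Neither step tests a cyclic amine carrying a phenyl ring on the same aromatic carbon, so the change in compound 4 is not directly covered. A move away from the cyclohexyl(methyl)amino group is expected to lower the number rather than raise it, though the larger entering group leaves the size of this uncertain.

For compound 4 a number around 400 nM is expected, within a range from 80 nM to 2000 nM. The step expected is a 3.0-fold lower number from compound 1 to compound 4 (0.48 log units; beyond the scatter).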

Compound 4, half-maximal effective concentration: 1770 nM
Beside the measured number, compound 4's estimate is 4.4-fold (0.65 log units) below it, and the stated range covers the measured number.
By their numbers in this assay, from the lowest: compounds 2 and 3 (each within the scatter of the next); then compounds 1 and 4 (each within the scatter of the next).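

In this assay, replacing cyclohexyl(methyl)amino with the cyclic 3-phenylpyrrolidin-1-yl group on this aromatic carbon gives a 1.5-fold higher number from compound 1 to compound 4 (0.17 log units; within the scatter) and so does not separate the two groups. The same replacement of the open-chain groups gives a 13-fold higher number from compound 3 to compound 4 (1.10 log units; beyond the scatter) and a 16-fold higher number from compound 2 to compound 4 (1.21 log units; beyond the scatter) for isopropyl(methyl)amino and dimethylamino, so among these four compounds the two groups bearing a six-membered ring of carbon only share the high end, with no compound against this. No supporting data bear on why these two groups fall together.

Still open, as far as these compounds go, is whether the phenyl ring or the five-membered ring accounts for the large steps from compound 2 and compound 3. An unsubstituted pyrrolidin-1-yl group or a morpholine ring on the same aromatic carbon would help separate these contributions.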